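Swapping Chloro for Methoxy in a Weakly Active Series

This account rests on a few compounds, and the source may have more. Where it says the series, first, only, none or still open, it means among the compounds named here.

Compound 1 `Fc1ccc(C2CC(c3ccc(Cl)cc3)=NN2c2ccc(-c3ccccc3)nn2)cc1` is measured in a functional assay on MCF7 cells (Homo sapiens) for antiproliferative activity, read by MTT assay, with a stated time of 24 h (on this read-out higher numbers stand for weaker inhibition and lower numbers for stronger inhibition), at 3750 nM. Compound 2 `COc1ccc(C2CC(c3ccc(Cl)cc3)=NN2c2ccc(-c3ccccc3)nn2)c(OC)c1` reaches only the assay limit in this assay, reported as > 100000 nM, which is a limit rather than a number. The step of an at least 26-fold higher number from compound 1 to compound 2 (1.42 log units; beyond the scatter) shows a large loss of activity. Compound 3 `COc1ccc(C2=NN(c3ccc(-c4ccccc4)nn3)C(c3ccc(OC)cc3OC)C2)cc1` differs from compound 2 by methoxy in place of chloro on an aromatic carbon. For the measured compounds named here, no measured step covers this change; the single measured step concerns a different aryl group. Compound 3 is expected to remain around the limit. The expected step is a step that the limit leaves unreadable from compound 2 to compound 3. Compound 3 is estimated at 150000 nM, between 40000 nM and 500000 nM.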

Compound 3, half-maximal inhibitory concentration: 100000 nM
The estimate for compound 3 lay 1.5-fold (0.18 log units) above the measured number; measured number inside the range.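

With 4-methoxyphenyl in place of 4-chlorophenyl, this assay gives a number no higher from compound 2 to compound 3 (the limit leaves the size open) and so reveals no recovery that can be sized at this position. For compound 2 the reported > 100000 nM is a limit, not a number. The size of this step therefore cannot be read: the limit of > 100000 nM in this assay, at which 1 of the 3 values shown sits.

Going by these compounds, it remains open whether an amine or a carboxylic acid in place of chloro would give a number clearly lower than the limit. On these data alone, the same change on compound 1, which has a measurable value, also remains open.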